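The source may report more compounds than this note shows. Statements on the series, on what has been measured and on what is new or still open speak of the compounds shown alone.

The measured compounds:
compound 1, `O=C(O)COc1cc(Cl)c(C(=O)Nc2cccc(-c3nc4ccccc4s3)c2)cc1[N+](=O)[O-]`, < 1 10^-6 cm/s
compound 2, `Cc1cc(NC(=O)c2cc([N+](=O)[O-])ccc2Cl)cc(-c2nc3ccccc3o2)c1O`, 105 10^-6 cm/s

In an ADME assay for permeability, using PAMPA, at pH 7.4 (a higher number here means that the compound crosses the layer faster, a lower number that the compound crosses the layer more slowly), compound 1 gives < 1 10^-6 cm/s, which is a limit of the assay and not a measured number. Going by these compounds, compound 1 thus stands at the limit of < 1 10^-6 cm/s in this assay, at which 1 of the 2 values shown sits, so its true place on the scale is unknown beyond that. Compound 2 in this assay gives 105 10^-6 cm/s. The account follows the step from compound 1 to compound 3, `O=C(Nc1cccc(-c2nc3ccccc3s2)c1)c1cc([N+](=O)[O-])ccc1Cl`, which has not yet been measured in this assay. The change is hydrogen in place of carboxymethoxy on an aromatic carbon. Among the compounds with values here, no step between measured compounds bears on this change directly, so the expectation rests on the values shown: compound 2, which also carries no carboxymethoxy group, gives 105 10^-6 cm/s. A large upward step is expected an at least 60-fold higher number from compound 1 to compound 3 (1.77 log units; beyond the scatter), well beyond the usual scatter. Compound 3 is therefore estimated at 60 10^-6 cm/s, in the range 15 10^-6 cm/s to 160 10^-6 cm/s.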

Compound 3, apparent permeability in the ADME assay: 12 10^-6 cm/s
Compound 3: the middle estimate sits 5.0-fold (0.70 log units) above what was measured, and the stated range ends above it.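

Within the data shown here, with compound 3, the carboxymethoxy group on this aromatic carbon, ortho to a nitro group and para to a large group, can for the first time be read against hydrogen on one core: in the ADME assay, the change gives an at least 12-fold higher number from compound 1 to compound 3 (1.07 log units; beyond the scatter). Compound 1 remains at a limit of the assay and not at a number: the limit of < 1 10^-6 cm/s in the ADME assay, at which 1 of the 3 values shown sits. In a physicochemical assay for solubility, read by spectrophotometry, in phosphate buffer, measured as kinetic solubility, with a stated time of 18 h, at pH 7.4 (a higher number here means a more soluble compound, a lower number a less soluble compound), compound 1 gives 6700 nM and compound 3 gives 580 nM, so the same change moves the number the other way: the measured solubility of compound 1, 6700 nM, and of compound 3, 580 nM, a 12-fold lower number (1.06 log units; beyond the scatter)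

The compounds shown leave open whether an amine or a methoxy group at this place would give numbers in the ADME assay and the physicochemical assay closer to those of compound 1 or to those of compound 3. Going by these compounds, they also leave open where the true value of compound 1 lies, so the full size of the step in the ADME assay remains unknown.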